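A few compounds are considered here, and "the series" means these few. Any claim that something is new, unique, unknown or untested is made for them only; others in the source may bear on it.

Measured compounds and their values:
- Compound 1, `C/C=C\C(=O)Nc1cc(Nc2nccc(-c3cn(C)c4ccccc34)n2)c(OC)cc1N(C)CCN(C)C`: 660 nM
- Compound 2, `CC/C=C\C(=O)Nc1cc(Nc2nccc(-c3cn(C)c4ccccc34)n2)c(OC)cc1N(C)CCN(C)C`: 1530 nM
- Compound 3, `CC/C=C\C(=O)Nc1cc(Nc2nc(C)cc(-c3cn(C)c4ccc(F)cc34)n2)c(OC)cc1N(C)CCN(C)C`: 9150 nM

All three were tested in a functional assay on A549 cells (Homo sapiens) for antiproliferative activity, read by MTT assay, with a stated time of 72 h; a lower number here means a stronger inhibitor, a higher number a weaker inhibitor. In this assay compound 1 gives 660 nM, and compound 2, which carries methyl in place of hydrogen on a saturated chain carbon bound to a double-bonded chain carbon, gives 1530 nM. That single change produced a 2.3-fold higher number from compound 1 to compound 2 (0.37 log units; beyond the scatter), a step beyond the usual scatter, so the longer chain on the amide weakened the inhibitor.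

Compound 3 gives 9150 nM, the highest number of the three. It shares the same amide chain as compound 2 but has a different core; the difference between the two cores is not broken down here.

Compound 4, `COc1cc(N(C)CCN(C)C)c(NC(=O)/C=C\C(C)C)cc1Nc1nc(C)cc(-c2cn(C)c3ccc(F)cc23)n1`, has not yet been measured. It differs from compound 3 by methyl in place of hydrogen on a saturated chain carbon bound to a double-bonded chain carbon and a saturated chain carbon. Among the measured compounds shown here, this is the same kind of change as the one from compound 1 to compound 2, not the same change: in the earlier pair the new methyl entered on a saturated chain carbon bound to a double-bonded chain carbon, whereas here it enters on a saturated chain carbon bound to a double-bonded chain carbon and a saturated chain carbon, so the chain grows by branching rather than by extension.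

Because the earlier step was a 2.3-fold higher number from compound 1 to compound 2 (0.37 log units; beyond the scatter), the expected step from compound 3 to compound 4 is a 1.7-fold higher number from compound 3 to compound 4 (0.24 log units; within the scatter), a further weakening of similar or slightly smaller size. Compound 4 is therefore estimated at 16000 nM in this assay, with a likely range from 7000 nM to 40000 nM.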

Compound 4, half-maximal inhibitory concentration: 9080 nM
Estimate against measurement, compound 4: 1.8-fold (0.25 log units) above; measured number inside the range.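

In this assay, putting a methyl in place of hydrogen on a saturated chain carbon bound to a double-bonded chain carbon and a saturated chain carbon, which turns ethyl into isopropyl at the end of the amide chain, gives a 1.0-fold lower number from compound 3 to compound 4 (0.00 log units; within the scatter), a step too small to read as any change. The earlier methyl step on the other core lay beyond the scatter, yet setting the two steps side by side does not separate them: the same change on two cores in this assay, a 2.3-fold higher number (0.37 log units; beyond the scatter) from compound 1 to compound 2 and a 1.0-fold lower number (0.00 log units; within the scatter) from compound 3 to compound 4, 2.3-fold (0.37 log units) apart, within the scatter of two such steps. Among the compounds shown here, this gives no firm sign that the core alters what an added methyl does here, but it does not prove that the effect carries over unchanged, as there is only one pair on each core and the chain grows by extension in one pair and by branching in the other.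

On these data alone, it remains open how the 3-methylbut-1-en-1-yl chain would read on the core of compound 1, a comparison that would set branching apart from the change of core. Also open, as far as these compounds go, is how a longer chain, such as propyl, or a ring such as cyclopropyl, would read at the same end of the amide chain on either core.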